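The source may hold more compounds than are shown below. What is called first, only, known or untested is meant among the compounds shown, and "the series" means these compounds.

Three compounds shown here share the same core, and each has been tested in an ADME assay on HUVEC cells (Homo sapiens) for inhibition, read by MTT assay, with a stated time of 48 h; a lower number here means a stronger inhibitor, a higher number a weaker inhibitor. Compound 1 `COc1ccccc1-c1csc(N/N=C/c2ccc(F)c(F)c2)n1` carries a 2-methoxyphenyl on that core. In this assay compound 1 reaches only the limit of the measurement, > 100000 nM. Compound 2 `Fc1ccc(/C=N/Nc2nc(-c3cccc(Br)c3)cs2)cc1F` is obtained from compound 1 by the change (3-bromophenyl in place of 2-methoxyphenyl on an aromatic carbon). In this assay compound 2 likewise gives only a limit, > 100000 nM. The step that the two limits leave unreadable from compound 1 to compound 2 is therefore one that cannot be sized from the two limits. Compound 3 `COc1ccccc1-c1csc(N/N=C/c2cc(OC)c(OC)c(Br)c2Br)n1` keeps the 2-methoxyphenyl of compound 1 but differs from it in more than one place; the difference between the two cores is not broken down here. In this assay compound 3 also sits at the limit, > 100000 nM. Compound 4 `COc1cc(/C=N/Nc2nc(-c3cccc(Br)c3)cs2)c(Br)c(Br)c1OC` is not yet measured; it arises from compound 3 by 3-bromophenyl in place of 2-methoxyphenyl on an aromatic carbon, the same change as that from compound 1 to compound 2, at a place described in identical words. Going by the values given here, because every value so far rests at the limit (the limit of > 100000 nM in this assay, at which 3 of the 3 values shown sit), the earlier step gives no readable size to lean on. The expected step from compound 3 to compound 4 is a step that the limit leaves unreadable from compound 3 to compound 4, resting on the unread step that the two limits leave unreadable from compound 1 to compound 2. Compound 4 is estimated at 150000 nM, most likely again reported only as a limit.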

Compound 4, half-maximal inhibitory concentration: > 100000 nM
Compound 4: a limit, no number; the forecaster's own chance of this, stated with the estimate: 85%; the middle value lies beyond the limit too.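

No size can be read for the step from compound 1 to compound 2 or for the same change from compound 3 to compound 4, because each of these compounds gives a limit rather than a number: the limit of > 100000 nM in this assay, at which 4 of the 4 values shown sit.

The compounds shown leave open whether 3-bromophenyl in place of 2-methoxyphenyl changes inhibition at all.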